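A few compounds are considered here, and "the series" means these few. Any claim that something is new, unique, unknown or untested is made for them only; others in the source may bear on it.

Measured compounds in the series:
- compound 1 `COc1cc(O)ccc1N1CCN(CC(O)COc2ccc(O)c3ccccc23)CC1`, > 50000 nM (a limit of the assay, not a number)
- compound 2 `Oc1ccc(N2CCN(CC(O)COc3ccc(O)c4ccccc34)CC2)c(O)c1`, 17900 nM
- compound 3 `Oc1ccc(N2CCN(CC(O)COc3cccc4ccccc34)CC2)c(O)c1`, 9600 nM

In a functional assay on KK-47 cells for antiproliferative activity against KK-47 cell line (Homo sapiens), read by MTT assay, with a stated time of 48 h (on this read-out higher numbers stand for weaker inhibition and lower numbers for stronger inhibition), compound 1 reaches only > 50000 nM, which is a limit of the assay rather than a number (the limit of > 50000 nM in this assay, at which 1 of the 3 values shown sits). Compound 2 stands at the highest number among the two measured values; its nearest neighbour is compound 3, separated by a 1.9-fold lower number from compound 2 to compound 3 (0.27 log units; within the scatter), so the two cannot be ordered against each other.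

The unmeasured compound 4 `COc1ccccc1N1CCN(CC(O)COc2ccc(O)c3ccccc23)CC1` is reached from compound 2 by 2-methoxyphenyl in place of 2,4-dihydroxyphenyl on an amine nitrogen in a ring. Going by the values given here, two measured steps bear on it. The change of hydrogen in place of methyl on an oxygen on an aromatic ring gave an at least 2.7-fold lower number from compound 1 to compound 2 (0.44 log units; beyond the scatter); compound 4 reverses that change, so the opposite direction is expected. The removal of a hydroxy on an aromatic carbon gave a 1.9-fold lower number from compound 2 to compound 3 (0.27 log units; within the scatter), which alone would mean no shift beyond the scatter. Taken together, a higher number is expected for compound 4 in this assay, with the shift from compound 2 estimated as a 2.8-fold higher number from compound 2 to compound 4 (0.45 log units; beyond the scatter), and a fair chance that compound 4 only reaches a limit, as compound 1 did.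

Compound 4 is thus estimated at 50000 nM, expected to fall between 15000 nM and 160000 nM.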

Compound 4, half-maximal inhibitory concentration: 17600 nM
Compound 4: middle estimate off by 2.8-fold (0.45 log units), on the high side; the range from low to high includes it.
By their numbers in this assay, from the lowest: compounds 3, 4 and 2 (each within the scatter of the next). At a limit, above all of these: compound 1.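

In this assay, the exchange of 2,4-dihydroxyphenyl for 2-methoxyphenyl on the amine nitrogen in a ring gives a 1.0-fold lower number from compound 2 to compound 4 (0.01 log units; within the scatter), so at this position the entering group, with no hydrogen-bond donors, leaves the number within the scatter of that of the dihydroxy group. The step that separates the methoxy-bearing pair, an at least 2.8-fold lower number from compound 1 to compound 4 (0.45 log units; beyond the scatter), shows that a methoxy group here does not by itself push the number to the top of the series, as compound 1 alone had suggested; among the compounds shown, only the methoxy and hydroxy groups together on this ring go with the weakest reading. The removal of a hydroxy on an aromatic carbon can be set beside its earlier counterpart only loosely: the same change on two cores in this assay, a 1.9-fold lower number (0.27 log units; within the scatter) from compound 2 to compound 3 and an at least 2.8-fold lower number (0.45 log units; beyond the scatter) from compound 1 to compound 4; the limit leaves it open whether they differ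

Going by these compounds, compound 1 stands at a limit of the assay, not at a number, so how far it lies from the others stays unknown: the limit of > 50000 nM in this assay, at which 1 of the 4 values shown sits. Also open is whether an unsubstituted phenyl, or a phenyl carrying an amine or a carboxylic acid, on this ring nitrogen would move the number beyond the scatter.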